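A few compounds are considered here, and "the series" means these few. Any claim that something is new, unique, unknown or untested is made for them only; others in the source may bear on it.

Of the compounds shown here, three built on a shared core have been tested in an ADME assay on HepG2 cells (Homo sapiens) for cytotoxicity, read by trypan blue exclusion, with a stated time of 48 h, in the presence of a further agent that is not named here; a higher number here means that more compound is tolerated, a lower number that less compound is tolerated. Compound 1 `COc1ccc(NC(=O)COc2cc(C)nc3ccc(OC)cc23)c(OC)c1` reaches only the limit of the measurement, giving > 131000 nM. Compound 2 `COc1cc(NC(=O)COc2cc(C)nc3ccc(OC)cc23)cc(OC)c1` likewise gives a limit, > 131000 nM. Compound 3 `COc1ccc2nc(C)cc(OCC(=O)Nc3ccc(Br)cc3)c2c1` gives a limit as well, namely > 125000 nM. Compound 3 thus stands where the other two stand: no number separates them, and all three sit at the edge of what the measurement can report, as shown by the limit of > 125000 nM in this assay, at which 1 of the 3 values shown sits, and (the limit of > 131000 nM in this assay, at which 2 of the 3 values shown sit). Within the data shown here, no step between measured compounds can be drawn from these values.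

Compound 4 `CCCCCNC(=O)COc1cc(C)nc2ccc(OC)cc12` differs from compound 3 by pentyl in place of 4-bromophenyl on an amide-type nitrogen. Among the measured compounds shown here, nothing measured tells how this change acts in this assay; the three limits give no direction, only that the shared core is tolerated up to the edge of the measurement. The step from compound 3 to compound 4 is therefore expected to be a step that the limit leaves unreadable from compound 3 to compound 4, which is to say none beyond the usual scatter. Compound 4 is expected to give 150000 nM, within a range from 60000 nM to 400000 nM, and most likely to be reported again only as a limit.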

Compound 4, half-maximal cytotoxic concentration: 106000 nM
Estimate against measurement, compound 4: 1.4-fold (0.15 log units) above; the measured number falls inside the stated range.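

Among these compounds, with pentyl in place of 4-bromophenyl on an amide-type nitrogen, compound 4 is the only one of the four compounds in this assay to give a number rather than a limit, namely 106000 nM. The change produces an at least 1.1-fold lower number from compound 3 to compound 4 (0.07 log units; that floor lies within the scatter), so only a floor for this step is known, and that floor does not show a real difference between the two compounds. Compound 3 itself remains a limit and not a number, which leaves the true size of the step unknown: the limit of > 125000 nM in this assay, at which 1 of the 4 values shown sits.

The compounds shown therefore leave open whether a number can be read for any compound with a ring on this nitrogen, and how far the value of compound 3 lies from the value of compound 4. They also leave open how the value at this position would respond to a shorter chain, a longer chain, or a pentyl chain ending in an amine or a carboxylic acid, since pentyl is the only open chain shown here.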